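The source may report more compounds than this note shows. Statements on the series, on what has been measured and on what is new or still open speak of the compounds shown alone.

Compound 1 `CC(=O)SCCC(CCCCC(=O)O)SC(C)=O`: 8.03%
Compound 2 `O=C(CCCCC(S)CCS)Nc1ccccc1`: 15.8%
Compound 3 `O=C(CCCCC(S)CCS)Nc1cccc(Cl)c1`: 8.04%

All three compounds were measured in a functional assay on KB cells (Homo sapiens) for inhibition, read by MTT assay, with a stated time of 24 h, tested at 100 ug/mL; on this read-out higher numbers stand for more inhibition of growth at the one concentration tested and lower numbers for less inhibition of growth. Compound 1 stands within the usual scatter of both compound 2 and compound 3, so the three values cannot be ranked. The account now turns to compound 4 `CC(=O)SCCC(CCCCC(=O)Nc1cccc(Cl)c1)SC(C)=O`, which keeps the core of compound 1 and differs from it in one place: (3-chlorophenyl)amino in place of hydroxy on a carbonyl carbon. In words, (3-chlorophenyl)amino stands in place of hydroxy on a carbonyl carbon.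

Going by the values given here, no measured step shows this exchange directly. Among the compounds with values here, the only measured step is a number 7.8 percentage points lower from compound 2 to compound 3 (within the scatter), and it concerns chloro in place of hydrogen on an aromatic carbon, so it bears on the new group only in part. That step lies within the scatter. Compound 3 already carries (3-chlorophenyl)amino, although on a core that differs from that of compound 1, and compound 3 gives 8.04%. This value lies within the scatter of the value for compound 1. The change is therefore expected to produce no step beyond the scatter, and no firm direction can be expected.

The estimate amounts to an expected a number 2 percentage points higher from compound 1 to compound 4 (within the scatter). In this assay, compound 4 is expected at 10%, with an estimated range from 3% to 22%.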

Compound 4, percent growth inhibition at one concentration: 48.8%
Compound 4: middle estimate off by 38.8 percentage points, on the low side, and the stated range ends below it.
By their numbers in this assay, from the lowest: compounds 1, 3 and 2 (each within the scatter of the next); then compound 4.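

In this assay, going by these compounds alone, the carbonyl carbon of the core of compound 1 proves to be a place where a change counts: (3-chlorophenyl)amino in place of hydroxy gives a number 40.8 percentage points higher from compound 1 to compound 4 (beyond the scatter) and so provides the first step in this set that lies beyond the scatter. Within the data shown here, the only step available before it (a number 7.8 percentage points lower from compound 2 to compound 3 (within the scatter)) concerned an aromatic carbon and left the earlier compounds unranked. Both groups count the same hydrogen-bond donors and no net charge, while the entering group adds a six-membered aromatic ring of carbon only and a chlorine, but nothing measured here explains the higher growth inhibition.

The compounds shown leave open how much of this step belongs to the aromatic ring and how much to the chloro, since on the core of compound 1 the carboxylic acid has only this one amide as a partner. A plain phenylamino or a methylamino group on the same carbonyl carbon would separate these parts, and a reading at a single concentration does not say how the step would appear across a range of concentrations.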